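A few compounds are considered here, and "the series" means these few. Any claim that something is new, unique, unknown or untested is made for them only; others in the source may bear on it.

Three compounds of one shared core were measured in a physicochemical assay for lipophilicity, read by HPLC, in phosphate buffer, measured as chromatographic lipophilicity, at pH 7.4; a higher number here means a more lipophilic compound, a lower number a more polar compound. Compound 1 `COc1ccc2c(OCC(=O)Nc3cc(C)cc(C)c3)cc(C)nc2c1` gives 5.59. Compound 2 `Cc1cc(C)cc(NC(=O)COc2cc(C)nc3ccc(F)cc23)c1` gives 5.79, which stands second highest of the three; its nearest neighbour is compound 1, whose number lies within the scatter of it, and the furthest is compound 3 `Cc1cc(C)cc(NC(=O)COc2cc(C)nc3ccc(C(F)(F)F)cc23)c1`, which gives 6.67. Among the measured compounds shown here, the only single-point step among the measured compounds is a number 0.88 log units higher from compound 2 to compound 3 (beyond the scatter), where trifluoromethyl replaces fluoro on an aromatic carbon.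

Compound 4 `Cc1cc(C)cc(NC(=O)COc2cc(C)nc3ccc(OC(F)(F)F)cc23)c1` is not yet measured. It differs from compound 2 in one place: trifluoromethoxy in place of fluoro on an aromatic carbon. For the measured compounds named here, the entering group is again fluorinated and larger than the fluoro it replaces, so the step from compound 2 to compound 3 is the one measured step that bears on it, and that step lay well beyond the scatter. In this assay compound 4 is therefore expected to come out clearly higher than compound 2, in the same direction and of about the same size, which is the step of a number 0.91 log units higher from compound 2 to compound 4 (beyond the scatter). The estimate for compound 4 in this assay is 6.7, with a range from 6.3 to 7.1.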

Compound 4, distribution coefficient: 6.79
The estimate for compound 4 lay 0.09 log units below the measured number; the measured number falls inside the stated range.
By their numbers in this assay, from the lowest: compounds 1 and 2 (each within the scatter of the next); then compounds 3 and 4 (each within the scatter of the next).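

In this assay a second fluorinated group on this aromatic carbon, meta to a fused ring and para to a fused ring, also moves the number clearly away from that of the fluoro compound, with a number 1.00 log units higher from compound 2 to compound 4 (beyond the scatter) and so in the same direction as the step to trifluoromethyl. The new comparison is between the two larger groups themselves: with a number 0.12 log units higher from compound 3 to compound 4 (within the scatter) and thus no readable difference, trifluoromethoxy and trifluoromethyl cannot be told apart at this place, and the oxygen that trifluoromethoxy brings, counted as a hydrogen-bond acceptor, leaves no mark on the number that can be read here. Nothing at hand gives a measured reason for either step.

Whether the rise extends to groups without fluorine on this same carbon, such as a nitrile, an amine or a carboxylic acid, stays open, as the steps shown cover only fluoro, trifluoromethyl and trifluoromethoxy. Also open, on these data alone, is whether trifluoromethoxy and trifluoromethyl would stay this close on another carbon of the shared core, or alongside a longer chain in place of the one that carries the amide.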